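A few compounds are considered here, and "the series" means these few. Any claim that something is new, unique, unknown or untested is made for them only; others in the source may bear on it.

Among the compounds with values here, only two compounds with the shared core have been measured so far, and they differ solely in their side chain. In a functional assay on HCT-116 cells (Homo sapiens) for antiproliferative activity, read by MTT assay, with a stated time of 48 h (on this read-out higher numbers stand for weaker inhibition and lower numbers for stronger inhibition), compound 1 `CCCC(CCO)n1cnc2c(Cl)nc(F)nc21` gives 16500 nM and compound 2 `CCCCCCCC(CCO)n1cnc2c(Cl)nc(F)nc21` gives 17600 nM. These two numbers lie within the scatter of each other, so compound 2 stands level with compound 1 and the data cannot separate them.

Compound 3 `CCCCCCCCC(CCO)n1cnc2c(Cl)nc(F)nc21` carries one further change on the same chain: methyl in place of hydrogen on a saturated chain carbon, eight bonds along the chain from an aromatic nitrogen. Put simply, this is methyl in place of hydrogen on a saturated chain carbon, eight bonds along the chain from an aromatic nitrogen.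

Within the data shown here, only one measured step bears on this, a 1.1-fold higher number from compound 1 to compound 2 (0.03 log units; within the scatter). That step added a butyl group to the chain and still left the number within the scatter. A single step is thin evidence, but the methyl change is the smaller addition, so no shift beyond the scatter is expected in this assay. The expected result is a 1.0-fold lower number from compound 2 to compound 3 (0.02 log units; within the scatter), a step that stays within the scatter. For compound 3 the estimated value is 17000 nM, with an expected range from 10000 nM to 28000 nM.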

Compound 3, half-maximal inhibitory concentration: 24200 nM
Beside the measured number, compound 3's estimate is 1.4-fold (0.15 log units) below it; measured number inside the range.
By their numbers in this assay, from the lowest: compounds 1, 2 and 3 (each within the scatter of the next).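

Methyl in place of hydrogen on a saturated chain carbon, eight bonds along the chain from an aromatic nitrogen, gives (a 1.4-fold higher number from compound 2 to compound 3 (0.14 log units; within the scatter)) in this assay, so this second spot on the chain, like the first, shows no shift that the data can separate from ordinary repeat-to-repeat variation. Read as one larger change, the two chain additions taken together give (a 1.5-fold higher number from compound 1 to compound 3 (0.17 log units; within the scatter)), which means that even they stay within the scatter and all three compounds remain level. No independent measurement bears on this result, so the finding rests on these numbers alone, with nothing to say what lies behind them.

From the compounds shown here alone, these three compounds differ only in plain carbon chains, so it remains open whether an amine or a carboxylic acid placed on the chain would shift the number beyond the scatter. A still longer chain is also an open case, as is whether the level values seen here would hold on any other cell line.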